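Moving the Ring Nitrogen in a Sulfonyl Pyridine

The source may report more compounds than this note shows. Statements on the series, on what has been measured and on what is new or still open speak of the compounds shown alone.

Measured compounds:
- compound 1, `CNCc1cc(-c2cccnc2F)n(S(=O)(=O)c2cccs2)c1`: 27 ng.h/mL
- compound 2, `CNCc1cn(S(=O)(=O)c2ccoc2)c(-c2cccnc2F)c1F`: 41 ng.h/mL
- compound 3, `CNCc1cn(S(=O)(=O)c2ncccc2C)c(-c2cccnc2F)c1F`: "not determined" (no result reported)

Three compounds have been through an ADME assay on the whole organism (plasma, Rattus norvegicus, strain Sprague-Dawley) for pharmacokinetics, read by LC-MS, using cassette dosing, at a dose of 0.2 mg/kg by the intravenous route; on this read-out lower numbers stand for lower exposure and higher numbers for higher exposure at the dose given. Compound 1 gives 27 ng.h/mL and compound 2 gives 41 ng.h/mL, two values that sit within the usual scatter of each other, so neither can be called higher or lower. Compound 3, which carries a methylpyridine on its sulfonyl sulfur, has no number at all in this assay, so it stands nowhere on the scale set by compounds 1 and 2.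

Compound 4, `CNCc1cn(S(=O)(=O)c2cnccc2C)c(-c2cccnc2F)c1F`, is the next step. The change from compound 3 is small: 4-methylpyridin-3-yl in place of 3-methylpyridin-2-yl on a sulfonyl sulfur. The same atoms are kept, only the ring nitrogen and the methyl group sit differently.

Among the measured compounds shown here, with no number for compound 3 and no measured pair that mirrors this change, there is nothing to size a step from. The expectation is that the step, if any, stays within the scatter of this assay, in no particular direction. Compound 4 is therefore expected to land near the two measured values, at an estimated 35 ng.h/mL, with a plausible range from 12 ng.h/mL to 100 ng.h/mL.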

Compound 4, area under the concentration-time curve: 41 ng.h/mL
Estimate against measurement, compound 4: 1.2-fold (0.07 log units) below, within the range that was stated.
By their numbers in this assay, from the lowest: compounds 1, 2 and 4 (each within the scatter of the next).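

In this assay, putting 4-methylpyridin-3-yl in place of furan-3-yl on a sulfonyl sulfur gives no change at the digits printed from compound 2 to compound 4 (within the scatter). Among the compounds shown here, this is the only measured pair here that differs in one place, and it shows that this position can carry either a five-membered ring with an oxygen or a six-membered ring with a nitrogen and a methyl group, with no readable difference in exposure at this dose in the rat. No separate measurement is available to explain this result.

With no number for compound 3, the effect of moving the ring nitrogen and the methyl group between 3-methylpyridin-2-yl and 4-methylpyridin-3-yl cannot be read, although that exchange is the closest structural comparison for compound 4. Also open, as far as these compounds go, is whether this position would still show no readable difference with a very different group on the sulfonyl sulfur, such as a plain phenyl ring, a short alkyl chain or a pyridine bearing a carboxylic acid.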